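Carbamoyl variation on the aromatic nitrogen: compound 4

A few compounds are considered here, and "the series" means these few. Any claim that something is new, unique, unknown or untested is made for them only; others in the source may bear on it.

Compound 1 `COc1cc(C(=O)NS(=O)(=O)c2ccccc2C)ccc1Cc1cn(C(F)F)c2ccc(NC(=O)OC3CCCC3)cc12` carries difluoromethyl on the aromatic nitrogen of the shared core; in an assay on isolated protein for binding affinity to cysteinyl leukotriene receptor 1 (Cavia porcellus) (a higher number here means a weaker inhibitor, a lower number a stronger inhibitor), compound 1 gives 1 nM. Compound 2 `COc1cc(C(=O)NS(=O)(=O)c2ccccc2C)ccc1Cc1cn(C(=O)N(C)C)c2ccc(NC(=O)OC3CCCC3)cc12` replaces that group with dimethylcarbamoyl, and in this assay compound 2 gives 0.4 nM. Compound 3 `COc1cc(C(=O)NS(=O)(=O)c2ccccc2C)ccc1Cc1cn(C(=O)NCCCc2ccccc2)c2ccc(NC(=O)OC3CCCC3)cc12` carries (3-phenylpropyl)carbamoyl at the same position, and in this assay compound 3 gives 0.5 nM. The steps read a 2.5-fold lower number from compound 1 to compound 2 (0.40 log units; beyond the scatter) and a 2.0-fold lower number from compound 1 to compound 3 (0.30 log units; within the scatter), while between the two carbamoyl compounds the step is a 1.3-fold higher number from compound 2 to compound 3 (0.10 log units; within the scatter).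

On the numbers shown, compound 3 stands second highest of three; its nearest neighbour is compound 2 and its furthest compound 1, and both gaps lie within the scatter.

Compound 4 `COc1cc(C(=O)NS(=O)(=O)c2ccccc2C)ccc1Cc1cn(C(=O)N2CCOCC2)c2ccc(NC(=O)OC3CCCC3)cc12` differs from compound 3 by morpholin-4-yl in place of (3-phenylpropyl)amino on a carbonyl carbon. Going by the values given here, the one measured step at this carbonyl carbon, a 1.3-fold higher number from compound 2 to compound 3 (0.10 log units; within the scatter), is within the scatter, and the two carbamoyl compounds differ from compound 1 only by a 2.5-fold lower number from compound 1 to compound 2 (0.40 log units; beyond the scatter) and a 2.0-fold lower number from compound 1 to compound 3 (0.30 log units; within the scatter). The change to compound 4 is therefore expected to give no step beyond the scatter, no change at the digits printed from compound 3 to compound 4 (within the scatter). Compound 4 is estimated at 0.5 nM, with a range from 0.2 nM to 1.2 nM.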

Compound 4, half-maximal inhibitory concentration: 0.4 nM
The estimate for compound 4 lay 1.3-fold (0.10 log units) above the measured number, within the range that was stated.
By their numbers in this assay, from the lowest: compounds 2, 4, 3 and 1 (each within the scatter of the next, the first and the last beyond it).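

In this assay the step from (3-phenylpropyl)amino to morpholin-4-yl on this carbonyl carbon reads a 1.3-fold lower number from compound 3 to compound 4 (0.10 log units; within the scatter) so the six-membered aromatic ring of carbon only and the hydrogen-bond donor of the leaving group are not needed to hold the number at this level. With dimethylamino on the same carbonyl carbon the comparison reads no change at the digits printed from compound 2 to compound 4 (within the scatter) which extends the earlier single comparison at this carbonyl carbon to a non-aromatic ring with 2 hetero atoms and leaves compounds 2, 3 and 4 all within the scatter of one another. Against difluoromethyl on the aromatic nitrogen the step is a 2.5-fold lower number from compound 1 to compound 4 (0.40 log units; beyond the scatter) as beyond the scatter as the step to compound 2, while compound 3 goes against any general reading of carbamoyl groups as better than difluoromethyl, its step being a 2.0-fold lower number from compound 1 to compound 3 (0.30 log units; within the scatter) and so within the scatter.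

Going by these compounds, how far this tolerance reaches stays open, for instance with a carboxylic acid or a longer chain ending in an amine on this carbonyl carbon. Nothing available here bears on why such different groups read alike in this assay.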